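The source may hold more compounds than are shown below. What is called first, only, known or untested is meant among the compounds shown, and "the series" means these compounds.

Measured in a functional assay on MIA PaCa-2 cells (Homo sapiens) for inhibition, read by MTT assay, with a stated time of 7 days; on this read-out lower numbers stand for stronger inhibition and higher numbers for weaker inhibition:
compound 1 `CC(C)S(=O)(=O)c1ccc(S(=O)(=O)N2CCC[C@@H](C(=O)N3CCC(F)(F)CC3)C2)cc1` — 11 nM
compound 2 `CCN(CC)S(=O)(=O)c1ccc(S(=O)(=O)N2CCC[C@@H](C(=O)N3CCC(F)(F)CC3)C2)cc1` — 16 nM

Going by the values given here, compound 2 lies within the scatter of compound 1, the only other number in this assay, so no separation between the two is claimed. Compound 3 `O=C([C@@H]1CCCN(S(=O)(=O)c2ccc(S(=O)(=O)N3CC[C@H](O)C3)cc2)C1)N1CCC(F)(F)CC1` differs from compound 2 by 3-hydroxypyrrolidin-1-yl in place of diethylamino on a sulfonyl sulfur. Among the compounds with values here, the single measured step at the same sulfonyl sulfur, a 1.5-fold higher number from compound 1 to compound 2 (0.16 log units; within the scatter), stayed within the scatter; no step that brings a hydroxyl group or a ring onto this sulfonyl sulfur has been measured. A small step in this assay is therefore expected, at most modestly toward a higher number. Compound 3 is expected to give 25 nM, range 8 nM to 80 nM, which means an expected 1.6-fold higher number from compound 2 to compound 3 (0.19 log units; within the scatter).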

Compound 3, half-maximal inhibitory concentration: 590 nM
Compound 3: the middle estimate sits 24-fold (1.37 log units) below what was measured, outside the stated range (above it).
By their numbers in this assay, from the lowest: compounds 1 and 2 (each within the scatter of the next); then compound 3.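

The sulfonyl sulfur is not indifferent to what it carries: in this assay, 3-hydroxypyrrolidin-1-yl in place of diethylamino gives (a 37-fold higher number from compound 2 to compound 3 (1.57 log units; beyond the scatter)), whereas the earlier change between isopropyl and diethylamino stayed within the scatter. In place of isopropyl, the same group gives (a 54-fold higher number from compound 1 to compound 3 (1.73 log units; beyond the scatter)), so the large step holds against both earlier groups. No evidence bears on the cause of this step.

The compounds shown leave open whether the step goes with the hydroxyl or with the ring. Unsubstituted pyrrolidin-1-yl at this sulfonyl sulfur would separate the two.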